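Arylpiperazine variation in the shared-core series

A few compounds are considered here, and "the series" means these few. Any claim that something is new, unique, unknown or untested is made for them only; others in the source may bear on it.

Three compounds on the shared core differ only in the aromatic group on the piperazine nitrogen. Compound 1 `O=C1c2ccccc2S(=O)(=O)N1CCCCCCN1CCN(c2ccccc2Cl)CC1` gives 459 nM in an ADME assay on HEK293 cells for displacement of a labelled ligand from 5-hydroxytryptamine receptor 6 (Homo sapiens), read by radioligand binding, with a stated time of 1 h; on this read-out lower numbers stand for stronger inhibition and higher numbers for weaker inhibition. Compound 2 `O=C1c2ccccc2S(=O)(=O)N1CCCCCCN1CCN(c2cccc(Cl)c2Cl)CC1` gives 920 nM in this assay, and compound 3 `O=C1c2ccccc2S(=O)(=O)N1CCCCCCN1CCN(c2ccccc2C(F)(F)F)CC1` gives 1270 nM. Compound 3 stands at the highest number of the three: a 2.8-fold higher number from compound 1 to compound 3 (0.44 log units; beyond the scatter), while a 1.4-fold higher number from compound 2 to compound 3 (0.14 log units; within the scatter) and a 2.0-fold higher number from compound 1 to compound 2 (0.30 log units; within the scatter).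

Compound 4 `O=C1c2ccccc2S(=O)(=O)N1CCCCCCN1CCN(c2cccc3cccnc23)CC1` is the next member, not yet measured. The change from compound 3: quinolin-8-yl in place of 2-(trifluoromethyl)phenyl on an amine nitrogen in a ring. For the measured compounds named here, none of the three measured steps covers an exchange of the whole aromatic group for a bicyclic one with a ring nitrogen; the only steps at hand are the small aryl swaps above, of which only the step to compound 3 from compound 1 went beyond the scatter. On that basis a modest step is expected, with a lower number slightly more likely than a higher one, though no direction is secured by the data. Compound 4 is expected at about 800 nM in this assay, within 250 nM to 2600 nM. The expected step is a 1.6-fold lower number from compound 3 to compound 4 (0.20 log units; within the scatter).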

Compound 4, inhibition constant: 1720 nM
Compound 4: middle estimate off by 2.2-fold (0.33 log units), on the low side; low and high end bracket the measured number.
By their numbers in this assay, from the lowest: compounds 1, 2, 3 and 4 (each within the scatter of the next, the first and the last beyond it).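

In this assay, quinolin-8-yl, which adds a second aromatic ring with a hetero atom on the amine nitrogen in a ring, cannot be told apart from 2-(trifluoromethyl)phenyl (a 1.4-fold higher number from compound 3 to compound 4 (0.13 log units; within the scatter)) or 2,3-dichlorophenyl (a 1.9-fold higher number from compound 2 to compound 4 (0.27 log units; within the scatter)). Only the comparison with 2-chlorophenyl separates (a 3.7-fold higher number from compound 1 to compound 4 (0.57 log units; beyond the scatter)), and that step is modest, so this position accepts a larger aromatic group with a ring nitrogen without a large change in the number, and none of the replacements for 2-chlorophenyl gives a lower number. Nothing at hand bears on the reason for these values.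

Open, on these data alone, is whether an unsubstituted phenyl or a 2-methoxyphenyl on the same nitrogen would give a number below that of compound 1 (459 nM). Also open, as far as these compounds go, is how a shorter chain on the shared core would shift the series.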